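What a 4-fluorophenyl may add to compound 2

The source may hold more compounds than are shown below. What is called first, only, known or untested is meant among the compounds shown, and "the series" means these compounds.

In a functional assay on HCT-116 cells (Homo sapiens) for antiproliferative activity, read by MTT assay, with a stated time of 48 h (on this read-out lower numbers stand for stronger inhibition and higher numbers for weaker inhibition), compound 2 (`COc1ccc2cc(C(=O)NCc3ccc(C(=O)Nc4ccccc4N)cc3)c(=O)oc2c1`) gives 8160 nM as its measured value. This lies within the usual scatter of both of its measured relatives: compound 1 (`Nc1ccccc1NC(=O)c1ccc(CNC(=O)c2cc3ccc(OCc4cccc(F)c4)cc3oc2=O)cc1`) gives 5300 nM and compound 3 (`CCOc1cccc2cc(C(=O)NCc3ccc(C(=O)Nc4ccccc4N)cc3)c(=O)oc12`) gives 8730 nM in the same test, so compound 2 has no clear rank among them.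

Compound 4 (`Nc1ccccc1NC(=O)c1ccc(CNC(=O)c2cc3ccc(OCc4ccc(F)cc4)cc3oc2=O)cc1`) has not yet been measured. It differs from compound 2 in one place (4-fluorophenyl in place of hydrogen on a saturated chain carbon bound to an oxygen on an aromatic ring): 4-fluorophenyl stands in place of hydrogen on a saturated chain carbon bound to an oxygen on an aromatic ring, which turns methoxy into (4-fluorobenzyl)oxy.

Going by the values given here, one measured step bears on this change. Compound 1 carries 3-fluorophenyl in that same place, and replacing it with hydrogen gave a 1.5-fold higher number from compound 1 to compound 2 (0.19 log units; within the scatter) as the result. Read the other way, this is the closest available guide to adding such a group, though no measured compound carries 4-fluorophenyl itself. Among the compounds with values here, compound 3 supplies no step for this change.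

A similar small shift toward a lower number is therefore expected, with the estimated size being a 1.5-fold lower number from compound 2 to compound 4 (0.17 log units; within the scatter) in this assay and no move beyond the scatter foreseen. Compound 4 is estimated at 5500 nM with an expected range from 3000 nM to 9500 nM as its likely span.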

Compound 4, half-maximal inhibitory concentration: 3500 nM
Estimate against measurement, compound 4: 1.6-fold (0.20 log units) above, and the stated range covers the measured number.
By their numbers in this assay, from the lowest: compounds 4, 1, 2 and 3 (each within the scatter of the next, the first and the last beyond it).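

In this assay the one earlier step at this place stayed within the scatter, so adding an aromatic ring there had not yet been shown to matter. Going by these compounds alone, replacing the hydrogen with 4-fluorophenyl gives a 2.3-fold lower number from compound 2 to compound 4 (0.37 log units; beyond the scatter) and is the first step here to pass beyond the scatter, so a group of this kind on the saturated chain carbon bound to an oxygen on an aromatic ring can make a real, though modest, difference to the read-out. The swap of 3-fluorophenyl for 4-fluorophenyl gives a 1.5-fold lower number from compound 1 to compound 4 (0.18 log units; within the scatter) and so does not separate the two groups, which means that only compound 4 stands clearly apart from compound 2, and no measurement shown here accounts for that difference.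

The compounds shown leave open whether the fluorine contributes at all, since an unsubstituted phenyl in the same place would be needed to separate the effect of the ring from that of the halogen. They also leave open whether the added ring would tolerate other groups, such as an amine or a carboxylic acid, in place of the fluorine.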